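A Trifluoromethoxy Swap on the Sulfonamide Aryl Ring

The source may hold more compounds than are shown below. What is called first, only, known or untested is meant among the compounds shown, and "the series" means these compounds.

Three compounds have been measured in an ADME assay on HEK293 cells (Homo sapiens) for cytotoxicity, read by MTT assay, with a stated time of 48 h; a higher number here means that more compound is tolerated, a lower number that less compound is tolerated:
Compound 1 `CCc1ccc(S(=O)(=O)NCCN2C(=O)C(c3ccc(O)cc3)=C(c3ccc(F)cc3)C2=O)cc1` gives 80400 nM
Compound 2 `CCc1ccc(S(=O)(=O)NCCCN2C(=O)C(c3ccc(O)cc3)=C(c3ccc(F)cc3)C2=O)cc1` gives 11500 nM
Compound 3 `O=C1C(c2ccc(O)cc2)=C(c2ccc(F)cc2)C(=O)N1CCCNS(=O)(=O)c1ccc(C(F)(F)F)cc1` gives 19700 nM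

Compound 3 stands second highest of the three: its nearest neighbour is compound 2, within the scatter, while compound 1 gives a higher number, beyond the scatter. Compound 4 `O=C1C(c2ccc(O)cc2)=C(c2ccc(F)cc2)C(=O)N1CCCNS(=O)(=O)c1ccc(OC(F)(F)F)cc1` differs from compound 3 by one change: trifluoromethoxy in place of trifluoromethyl on an aromatic carbon. Among the compounds with values here, one measured step touches the same aromatic carbon, a 1.7-fold higher number from compound 2 to compound 3 (0.23 log units; within the scatter), and it stayed within the scatter. The step to compound 4 in this assay is expected to be small as well, a 1.0-fold higher number from compound 3 to compound 4 (0.01 log units; within the scatter), because a 1.7-fold higher number from compound 2 to compound 3 (0.23 log units; within the scatter) changed the number by no more than the scatter. Compound 4 is therefore estimated at 20000 nM, with a range from 8000 nM to 50000 nM.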

Compound 4, concentration lethal to 50% of the cells: 24800 nM
Compound 4: middle estimate off by 1.2-fold (0.09 log units), on the low side; low and high end bracket the measured number.
By their numbers in this assay, from the lowest: compounds 2, 3 and 4 (each within the scatter of the next, the first and the last beyond it); then compound 1.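

In this assay, trifluoromethoxy and trifluoromethyl at this aromatic carbon cannot be told apart, with a 1.3-fold higher number from compound 3 to compound 4 (0.10 log units; within the scatter) as the step between them. Measured against ethyl, however, trifluoromethoxy gives a 2.2-fold higher number from compound 2 to compound 4 (0.33 log units; beyond the scatter) and so passes the scatter, which a 1.7-fold higher number from compound 2 to compound 3 (0.23 log units; within the scatter) does not. Nothing measured here gives a reason for these steps.

The compounds shown leave open whether an amine or a carboxylic acid at this aromatic carbon would shift the number further. They also leave open whether these swaps would give similar steps on the shorter chain of compound 1.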